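Methoxy for amino on the shared core

This account rests on a few compounds, and the source may have more. Where it says the series, first, only, none or still open, it means among the compounds named here.

Compound 1 `Nc1cccc(-c2cn(CC(=O)NCc3ccccc3)nn2)c1` stands highest of the two numbers in hand in an ADME assay on cells (spleen, Mus musculus, strain C57BL/6) for inhibition, read by flow cytometry and propidium iodide staining, with a stated time of 24 h, at 37 degrees C (a lower number here means that less compound is needed, a higher number that more compound is needed for the effect), with compound 1 giving 800 uM. Compound 2 `O=C(Cn1cc(C(=O)OCc2ccccc2)nn1)NCc1ccccc1` gives 720 uM in this assay, a gap to compound 1 that lies within the scatter, so no order between the two is claimed. Compound 3 `O=C(Cn1cc(-c2ccccc2C(F)(F)F)nn1)NCc1ccccc1` is recorded in this assay only as "non-toxic" (no number reported), without a number. Compound 4 `COc1cccc(-c2cn(CC(=O)NCc3ccccc3)nn2)c1` differs from compound 1 by methoxy in place of amino on an aromatic carbon. Among the measured compounds shown here, no step between measured compounds exists in this set, so the change is judged from the structural change alone; an expected step of no more than the scatter, in no preferred direction, is set as no change at the digits printed from compound 1 to compound 4 (within the scatter). For compound 4 the value in this assay is estimated at 800 uM, between 400 uM and 1600 uM.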

Compound 4, concentration for half-maximal effect: 840 uM
Beside the measured number, compound 4's estimate is 1.1-fold (0.02 log units) below it; low and high end bracket the measured number.
By their numbers in this assay, from the lowest: compounds 2, 1 and 4 (each within the scatter of the next).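

Among the compounds shown here, the first step at this place, 3-aminophenyl to 3-methoxyphenyl in this assay, gives a 1.1-fold higher number from compound 1 to compound 4 (0.02 log units; within the scatter) and so shows that on the shared core this exchange, which gives up the hydrogen-bond donor of amino, does not move the number beyond the scatter. No measured evidence on the cause accompanies this result.

Open, on these data alone, is whether a carboxylic acid or a longer alkoxy chain at this place would move the number in this assay beyond the scatter. Also open, as far as these compounds go, is whether the same exchange reads alike on another core.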